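Replacing the aryl group of a GIP receptor agonist

The source may hold more compounds than are shown below. What is called first, only, known or untested is meant among the compounds shown, and "the series" means these compounds.

Measured so far:
- compound 1 `CC(C)OC(=O)N1CCC(Oc2ncnc3c2CCN3c2ccc(S(C)(=O)=O)cc2F)CC1`: 50.1 nM
- compound 2 `CCS(=O)(=O)N1CCC(Oc2ncnc3c2CCN3c2ccc(S(C)(=O)=O)cc2F)CC1`: 1580 nM

In a functional assay on CHO-K1 cells for agonist activity at Glucose-dependent insulinotropic receptor (Homo sapiens), read by a luciferase reporter, with a stated time of 5 h (on this read-out lower numbers stand for an effect already at smaller amounts and higher numbers for an effect only at larger amounts of compound), compound 1 gives 50.1 nM, the lowest of the two numbers shown; its only neighbour is compound 2, which gives 1580 nM. Among the compounds with values here, the one measured step, a 32-fold higher number from compound 1 to compound 2 (1.50 log units; beyond the scatter), concerns the group on the amine nitrogen in a ring and is large.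

Compound 3 `CC(C)OC(=O)N1CCC(Oc2ncnc3c2CCN3c2ccc(C#N)cn2)CC1` differs from compound 1 elsewhere: 5-cyanopyridin-2-yl in place of 2-fluoro-4-(methylsulfonyl)phenyl on a nitrogen on an aromatic ring in a ring. Within the data shown here, no measured step touches this part of the shared core, so the step from compound 1 to compound 2 gives no direct guide, and the expectation must rest on compound 1 alone with a wide range. For compound 3 the estimated value in this assay is 120 nM, expected between 20 nM and 800 nM, which amounts to an expected step of a 2.4-fold higher number from compound 1 to compound 3 (0.38 log units; beyond the scatter).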

Compound 3, half-maximal effective concentration: 794 nM
Compound 3: middle estimate off by 6.6-fold (0.82 log units), on the low side; the measured number falls inside the stated range.
By their numbers in this assay, from the lowest: compound 1; then compounds 3 and 2 (each within the scatter of the next).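

In this assay, changing 2-fluoro-4-(methylsulfonyl)phenyl to 5-cyanopyridin-2-yl gives a 16-fold higher number from compound 1 to compound 3 (1.20 log units; beyond the scatter), so the group on this nitrogen matters as well as the group on the amine nitrogen in a ring. Within the data shown here, this large step is the first measured change at this position, and with the isopropoxycarbonyl group held constant, the 5-cyanopyridin-2-yl group does not match the group it replaces. No evidence is at hand to explain the size of this step.

The swap changes the ring, its fluorine and its methylsulfonyl group together, so the compounds shown do not separate their contributions. From the compounds shown here alone, a 2-fluoro-4-cyanophenyl group or a pyridine ring carrying methylsulfonyl could do so, and it remains open whether ethylsulfonyl on the amine nitrogen would have the same effect alongside 5-cyanopyridin-2-yl.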